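This account rests on a few compounds, and the source may have more. Where it says the series, first, only, none or still open, it means among the compounds named here.

Compound 1 `COc1ccc(-c2ccc(C(=O)NCCCCc3cccnc3)cc2OC)cc1OC` gives 300 nM in an assay (Canis lupus familiaris) for binding affinity to platelet-activating factor receptor (Homo sapiens), read by radioligand binding; on this read-out higher numbers stand for weaker inhibition and lower numbers for stronger inhibition. Compound 2 `CCc1cc(C(=O)N[C@H](C)CCCc2cccnc2)ccc1-c1ccc(OC)c(OC)c1` gives 4 nM in this assay.

Of the two compounds measured, compound 2 has the lower number, and the gap up to compound 1 lies well beyond the usual scatter. Compound 3 `CCCCc1cc(C(=O)N[C@H](C)CCCc2cccnc2)ccc1-c1ccc(OC)c(OC)c1` follows from compound 2 by ethyl in place of hydrogen on a saturated chain carbon, two bonds along the chain from an aromatic carbon. Among the compounds with values here, no pair of measured compounds shows this change, so its effect is not known here. Compound 3 is expected to stay close to compound 2, with a step of a 1.8-fold higher number from compound 2 to compound 3 (0.24 log units; within the scatter) that is at most modest. The estimate for compound 3 in this assay is 7 nM, within a range from 1.5 nM to 30 nM.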

Compound 3, half-maximal inhibitory concentration: 4 nM
Compound 3: the middle estimate sits 1.8-fold (0.24 log units) above what was measured; measured number inside the range.
By their numbers in this assay, from the lowest: compounds 2 and 3 (each within the scatter of the next); then compound 1.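

In this assay, there is no change at the digits printed from compound 2 to compound 3 (within the scatter) for ethyl in place of hydrogen on a saturated chain carbon, two bonds along the chain from an aromatic carbon, so the ethyl of compound 2 can give way to the butyl of compound 3 without a visible shift. Compound 1 differs from compound 2 in more than one place, so it could not show this. Nothing available here explains why the number holds. From the compounds shown here alone, whether a longer chain, or an amine or a carboxylic acid in place of the butyl, would also leave the number unchanged stays open.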